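Swapping a bromo-hydroxyphenyl for a hydroxynaphthyl

This account rests on a few compounds, and the source may have more. Where it says the series, first, only, none or still open, it means among the compounds named here.

Of the compounds shown here, three sharing one core have been tested in a functional assay on MKN-45 cells (Homo sapiens) for cytotoxicity, read by MTT assay, with a stated time of 72 h; on this read-out lower numbers stand for stronger inhibition and higher numbers for weaker inhibition. Compound 1 `CN(C)CCn1cnnc1-c1cc(Oc2ccc(NC(=O)N/N=C/c3ccc(O)c(F)c3)cc2F)ccn1` gives 1970 nM. Compound 2 `CN(C)CCn1cnnc1-c1cc(Oc2ccc(NC(=O)N/N=C/c3ccc(O)c(O)c3)cc2F)ccn1` gives 3240 nM, and compound 3 `CN(C)CCn1cnnc1-c1cc(Oc2ccc(NC(=O)N/N=C/c3ccc(O)c(Br)c3)cc2F)ccn1` gives 1860 nM. Compound 3 holds the lowest of the three numbers, yet both neighbours sit within the scatter of it: a 1.1-fold lower number from compound 1 to compound 3 (0.02 log units; within the scatter) and a 1.7-fold lower number from compound 2 to compound 3 (0.24 log units; within the scatter). For the measured compounds named here, the one step not involving compound 3, a 1.6-fold higher number from compound 1 to compound 2 (0.22 log units; within the scatter), is likewise within the scatter.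

Compound 4 `CN(C)CCn1cnnc1-c1cc(Oc2ccc(NC(=O)N/N=C/c3c(O)ccc4ccccc34)cc2F)ccn1` is not yet measured. It differs from compound 3 in one place: 2-hydroxynaphthalen-1-yl in place of 3-bromo-4-hydroxyphenyl on a carbon with a double bond to nitrogen. The three measured steps all exchange one substituent on the same aromatic ring and none moved the number beyond the scatter, so this read-out has so far tolerated changes there. Going by the values given here, the change to compound 4 is larger, adding a second fused ring and removing the bromo, and no measured step tests that directly.

The expectation is therefore a number close to that of compound 3, with a 1.2-fold higher number from compound 3 to compound 4 (0.07 log units; within the scatter) as the estimated step. Compound 4 is estimated at 2200 nM, with a range from 900 nM to 5500 nM in this assay.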

Compound 4, half-maximal inhibitory concentration: 2020 nM
For compound 4 the middle estimate is 1.1-fold (0.04 log units) above the measured one; the range from low to high includes it.
By their numbers in this assay, from the lowest: compounds 3, 1, 4 and 2 (each within the scatter of the next).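

In this assay, the exchange goes beyond a single substituent on the ring: the whole group on the carbon with a double bond to nitrogen becomes 2-hydroxynaphthalen-1-yl, with a second aromatic ring and no bromine, yet the number stays within the scatter of all three earlier compounds, with a 1.1-fold higher number from compound 3 to compound 4 (0.04 log units; within the scatter), a 1.6-fold lower number from compound 2 to compound 4 (0.21 log units; within the scatter) and a 1.0-fold higher number from compound 1 to compound 4 (0.01 log units; within the scatter). This read-out therefore does not separate the one-ring groups from the two-ring group at this position. Nothing measured here bears on why the number holds so steady.

As far as these compounds go, all four groups at this position carry a hydroxy on an aromatic ring, so the role of that hydroxy remains open, and a plain naphthalen-1-yl or a ring bearing an amine or a carboxylic acid instead would test it. Also open, from the compounds shown here alone, is whether any change at this position can move the number beyond the scatter.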